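Removing the phenol from a trimethoxy cinnamide analogue

The source may report more compounds than this note shows. Statements on the series, on what has been measured and on what is new or still open speak of the compounds shown alone.

Of the compounds shown here, three sharing one core have been tested in an assay for inhibition of Polyunsaturated fatty acid 5-lipoxygenase (Homo sapiens), read by spectrophotometry, tested at 20 uM; a higher number here means more inhibition at the concentration tested (going by the name of the read-out), a lower number less inhibition. Compound 1 `COc1cc(/C=C/C=C/C(=O)N2CCCCC2)cc(OC)c1OC` gives 66.7%, compound 2 `COc1cc(/C=C/C=C/C(=O)N2CCCCC2)cc(OC)c1O` gives 32.7%, and compound 3 `COc1cc(/C=C/C=C/C(=O)N2CCCCC2)ccc1O` gives 55.5%. Compound 2 thus stands lowest of the three numbers: compound 3 lies nearest, and compound 1 furthest, both beyond the scatter of this assay.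

Compound 4 `COc1cc(/C=C/C=C/C(=O)N2CCCCC2)cc(OC)c1` has not yet been measured. It differs from compound 2 by a single change, (hydrogen in place of hydroxy on an aromatic carbon), sited on an aromatic carbon of the six-membered aromatic ring, ortho to two methoxy groups and para to a large group.

Going by the values given here, two measured steps bear on this change. Swapping the hydroxy hydrogen for methyl gave a number 34 percentage points lower from compound 1 to compound 2 (beyond the scatter) read in reverse, meaning that capping the phenol raised inhibition markedly. Taking a methoxy off compound 2 gave a number 22.8 percentage points higher from compound 2 to compound 3 (beyond the scatter). Each change away from the free phenol of compound 2 therefore moved inhibition upward, and removing the hydroxy altogether is expected to do the same. Compound 4 is expected to show a rise of a number 25.3 percentage points higher from compound 2 to compound 4 (beyond the scatter), landing at an estimated 58% with a range from 40% to 75%.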

Compound 4, a percentage reported as inhibition, at one concentration (the size of the read-out at that concentration, not a potency): 64.9%
For compound 4 the middle estimate is 6.9 percentage points below the measured one; the measured number falls inside the stated range.
By their numbers in this assay, from the lowest: compound 2; then compounds 3, 4 and 1 (each within the scatter of the next, the first and the last beyond it).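

Removing the hydroxy from this ring carbon, ortho to two methoxy groups, gives a number 32.2 percentage points higher from compound 2 to compound 4 (beyond the scatter), whereas removing a methoxy group from the same carbon gives a number 1.8 percentage points lower from compound 1 to compound 4 (within the scatter). Hydrogen and methoxy at this position therefore cannot be told apart in this assay, and on this core, with both methoxy groups present, the hydroxy of compound 2 alone goes with a low number. Compound 3 shows that this low number does not belong to the hydroxy by itself, as it also has a free hydroxy yet lost a methoxy group with a very different outcome from compound 1, so the same change depends on what else the ring carries: the same change on two cores in this assay, a number 22.8 percentage points higher (beyond the scatter) from compound 2 to compound 3 and a number 1.8 percentage points lower (within the scatter) from compound 1 to compound 4, 24.6 percentage points apart, beyond the scatter of two such steps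

As far as these compounds go, it remains open whether an amine, a carboxylic acid or a fluorine on this carbon would behave like the hydroxy of compound 2 or like the hydrogen and methoxy of compounds 4 and 1. From the compounds shown here alone, each number in this assay also comes from a single concentration, so any difference in potency between compound 4 and compound 1 stays unknown.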